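Series notes: from compound 2 toward compound 4

A few compounds are considered here, and "the series" means these few. Any claim that something is new, unique, unknown or untested is made for them only; others in the source may bear on it.

Measured so far in a functional assay on MIA PaCa-2 cells (Homo sapiens) for inhibition, read by MTT assay, with a stated time of 72 h; on this read-out lower numbers stand for stronger inhibition of growth and higher numbers for weaker inhibition of growth:
- compound 1, `O=S(=O)(NCCNCc1cccc2ccccc12)c1cc(C(F)(F)F)cc(C(F)(F)F)c1`: compound 1 gives 26000 nM
- compound 2, `O=S(=O)(NCCCNCc1ccccc1Cl)c1cc(C(F)(F)F)cc(C(F)(F)F)c1`: compound 2 gives 11000 nM
- compound 3, `CCCCc1ccc(S(=O)(=O)NCCCCCCNCc2ccc(Br)cc2)cc1`: compound 3 gives 5700 nM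

Compound 2 stands second highest of the three numbers. Its nearest neighbour is compound 3, whose value of 5700 nM lies within the scatter of that of compound 2; the furthest is compound 1, whose value of 26000 nM lies beyond the scatter above compound 2.

Compound 4, `O=S(=O)(NCCCNCc1ccc(C(F)(F)F)cc1)c1cc(C(F)(F)F)cc(C(F)(F)F)c1`, is not yet measured. It differs from compound 2 in one place: 4-(trifluoromethyl)phenyl in place of 2-chlorophenyl on a saturated chain carbon bound to an amine nitrogen. Going by the values given here, no pair among the measured compounds differs in the same way, so there is no measured step to lean on for this change.

On that basis the step of a 1.2-fold lower number from compound 2 to compound 4 (0.09 log units; within the scatter) is expected to be small, if anything toward a slightly lower number, and not clearly beyond the scatter. Compound 4 is therefore estimated at 9000 nM in this assay, with a range from 3000 nM to 30000 nM.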

Compound 4, concentration for 50% growth inhibition: 2500 nM
For compound 4 the middle estimate is 3.6-fold (0.56 log units) above the measured one; the measured number lies below the stated range.
By their numbers in this assay, from the lowest: compound 4; then compounds 3 and 2 (each within the scatter of the next); then compound 1.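

In this assay the change to 4-(trifluoromethyl)phenyl in place of 2-chlorophenyl gives a 4.4-fold lower number from compound 2 to compound 4 (0.64 log units; beyond the scatter), so the aryl group on a saturated chain carbon bound to an amine nitrogen affects growth inhibition in this cell line. The earlier compounds shown here could not show this, as no two of them differ in only one place, and this pair isolates the aryl group with the rest of the structure held constant. Nothing at hand accounts for the size or direction of this step.

This single pair changes the substituent and its place on the ring together, leaving open which of the two goes with the step. Unsubstituted phenyl at the same carbon would give a reference point for both groups, and a longer chain carrying 4-(trifluoromethyl)phenyl would show whether the step holds on a different linker.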